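The source may report more compounds than this note shows. Statements on the series, on what has been measured and on what is new or still open speak of the compounds shown alone.

Compound 1 `C=CCNC(=O)[C@@H](NC(=O)[C@@](O)(CCCN(Cc1ccc(Br)cc1)NC(=O)[C@@H](NC(=O)OC)C(C)(C)C)Cc1ccc(Br)cc1)C(C)C` and compound 2 `C=CCNC(=O)[C@@H](NC(=O)[C@@](O)(CCCN(Cc1ccc(Br)cc1)NC(=O)[C@@H](NC(=O)OC)C(C)(C)C)Cc1ccc(Br)cc1)C(C)(C)C` are built on one core, while compound 3 `COC(=O)N[C@H](C(=O)NN(CCC[C@@]1(O)Cc2ccc(cc2)C/C=C\CNC(=O)[C@H](C(C)C)NC1=O)Cc1ccc(Br)cc1)C(C)(C)C` and compound 4 `COC(=O)N[C@H](C(=O)NN(CCC[C@@]1(O)Cc2ccc(cc2)C/C=C\CNC(=O)[C@H](C(C)(C)C)NC1=O)Cc1ccc(Br)cc1)C(C)(C)C` are built on another; the difference between the two cores is not broken down here. In an ADME assay on MT4 cells (Homo sapiens) for cytotoxicity, read by XTT assay, with a stated time of 5 days (on this read-out higher numbers stand for lower toxicity in this test and lower numbers for higher toxicity in this test), compound 1 gives 22000 nM. In this assay compound 2 gives 29000 nM. The change methyl in place of hydrogen on a saturated chain carbon bound to three saturated chain carbons thus produced a 1.3-fold higher number from compound 1 to compound 2 (0.12 log units; within the scatter). In this assay compound 3 gives > 50000 nM, which is a limit of the assay rather than a number. That value sits at the limit of > 50000 nM in this assay, at which 1 of the 3 values shown sits. Compound 4 differs from compound 3 by methyl in place of hydrogen on a saturated chain carbon bound to two saturated chain carbons and a saturated ring carbon, the same kind of change, although here the place is a saturated chain carbon bound to two saturated chain carbons and a saturated ring carbon instead of three saturated chain carbons. Given a 1.3-fold higher number from compound 1 to compound 2 (0.12 log units; within the scatter), compound 4 is expected to show a step that the limit leaves unreadable from compound 3 to compound 4. In this assay compound 4 is therefore estimated at about 60000 nM, most probably reported again only as a limit.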

Compound 4, half-maximal cytotoxic concentration: 30000 nM
Compound 4: middle estimate off by 2.0-fold (0.30 log units), on the high side, and the stated range ends above it.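

In this assay the value of compound 3, > 50000 nM, is a limit of the assay and not a number. The change from isopropyl to tert-butyl on this core therefore gives an at least 1.6-fold lower number from compound 3 to compound 4 (0.22 log units; that floor lies within the scatter); this is only a floor, and the true step may be larger. Set beside the same change on the core of compound 1, this result shows neither that the change carries over from one core to the other nor that it does not: the same change on two cores in this assay, a 1.3-fold higher number (0.12 log units; within the scatter) from compound 1 to compound 2 and an at least 1.6-fold lower number (0.22 log units; that floor lies within the scatter) from compound 3 to compound 4; the limit leaves it open whether they differ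

The compounds shown leave open how large the step on this core really is. They also leave open what an ethyl or a cyclohexyl group in the same place would give in this assay.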